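The source may report more compounds than this note shows. Statements on the series, on what has been measured and on what is new or still open speak of the compounds shown alone.

The series shares one core, seen in compound 2 `CCCSc1nc(N)nc2c1ncn2/C=C1/CC1(CO)CO`. In an ADME assay on Akata cells (Homo sapiens) for cytotoxicity, with a stated time of 7 days (a lower number here means that less compound is tolerated, a higher number that more compound is tolerated), compound 2 gives only a limit, > 20000 nM. Compound 1 `C=CCOc1nc(N)nc2c1ncn2/C=C1/CC1(CO)CO` likewise gives only a limit in this assay, > 20000 nM. Compound 3 `CC(C)Nc1nc(N)nc2c1ncn2/C=C1/CC1(CO)CO` in this assay returns a limit as well, > 24000 nM. Two of the three values sit at the limit of > 20000 nM in this assay, at which 2 of the 3 values shown sit, and the third at the limit of > 24000 nM in this assay, at which 1 of the 3 values shown sits, so compound 2 stands, like the others, at a limit and not at a number.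

Compound 4 `CCCCOc1nc(N)nc2c1ncn2/C=C1/CC1(CO)CO` carries butoxy in place of propylsulfanyl on an aromatic carbon. The steps that might guide this change are a step that the two limits leave unreadable from compound 1 to compound 2, a step that the two limits leave unreadable from compound 2 to compound 3 and a step that the two limits leave unreadable from compound 1 to compound 3; none of them can be read as a size, since each joins two limits. Among the measured compounds shown here, no measured step sets an expected size or direction for the change from compound 2 to compound 4 in this assay, and the only guide is that every compound measured so far reached a limit, with nothing among compounds 1, 2 and 3 going against that picture.

Compound 4 is therefore expected to give 40000 nM in this assay, with a range from 15000 nM to 150000 nM, and most likely to be reported again only as a limit. This amounts to an expected step that the limit leaves unreadable from compound 2 to compound 4.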

Compound 4, half-maximal cytotoxic concentration: > 20000 nM
Compound 4 gave a limit, no number (the forecaster's own chance of this, stated with the estimate: 85%); the middle value does not contradict the limit.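

Compound 4, like compound 1, compound 2 and compound 3, gives only a limit in this assay, so none of the steps joining compound 4 to those three compounds can be read as a size. The compounds shown leave open at what concentration any of the four becomes cytotoxic to these cells, and whether the changes on the aromatic carbon alter that concentration at all.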